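Adding methoxy to compound 2

This account rests on a few compounds, and the source may have more. Where it says the series, first, only, none or still open, it means among the compounds named here.

- compound 1 `COc1ccc(/C=C/c2cc(C)no2)cc1OC` at 63200 nM
- compound 2 `Cc1cc(/C=C/c2ccc(O)cc2)on1` at 50200 nM

In an ADME assay on HEK293 cells (Homo sapiens) for cytotoxicity, read by MTT assay, with a stated time of 72 h (a lower number here means a stronger inhibitor, a higher number a weaker inhibitor), compound 2 at 50200 nM lies within the scatter of compound 1, so neither stands apart. Compound 3 `COc1cc(/C=C/c2cc(C)no2)ccc1O` differs from compound 2 by methoxy in place of hydrogen on an aromatic carbon (methoxy in place of hydrogen on an aromatic carbon, ortho to a hydroxy group). Among the measured compounds shown here, no measured step is available, and compound 1 at 63200 nM is the only other reference, so no change beyond the scatter is expected in this assay here. The expected move is a 1.1-fold higher number from compound 2 to compound 3 (0.04 log units; within the scatter) and stays within the scatter. Compound 3 is estimated at 55000 nM (expected range 22000 nM to 120000 nM).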

Compound 3, half-maximal inhibitory concentration: 36200 nM
The estimate for compound 3 lay 1.5-fold (0.18 log units) above the measured number; the measured number falls inside the stated range.
By their numbers in this assay, from the lowest: compounds 3, 2 and 1 (each within the scatter of the next).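

In this assay methoxy in place of hydrogen on an aromatic carbon, ortho to a hydroxy group, gives a 1.4-fold lower number from compound 2 to compound 3 (0.14 log units; within the scatter) and so shifts the number no further than the scatter at this position. Hydrogen in place of methyl on an oxygen on an aromatic ring gives a 1.7-fold lower number from compound 1 to compound 3 (0.24 log units; within the scatter) and also stays within the scatter, so this change separates compound 1 and compound 3 by no reliable margin. Nothing measured here offers an explanation for either step.

Going by these compounds, whether an amine or a carboxylic acid at this position would also stay within the scatter remains open. So does whether any change at this position can move the number beyond the scatter.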